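A few compounds are considered here, and "the series" means these few. Any claim that something is new, unique, unknown or untested is made for them only; others in the source may bear on it.

Measured compounds:
Compound 1 `CCn1nnc(-c2sc(-c3cccc(N)c3)nc2O)n1`: 61 nM
Compound 2 `Cc1nnc(-c2sc(-c3cccc(F)c3)nc2O)o1`: 9100 nM

Of the two numbers in an assay on HEK293 cells for inhibition of transient receptor potential cation channel subfamily M member 8 (Homo sapiens), read by FLIPR, with stated times of 5 min and 3 min (a higher number here means a weaker inhibitor, a lower number a stronger inhibitor), compound 1 holds the lowest, and compound 2 is its nearest neighbour, with a value far beyond the scatter above it. Compound 3 `CCn1nnc(-c2sc(-c3cccc(OC)c3)nc2O)n1` keeps the core of compound 1 and differs in one place: methoxy in place of amino on an aromatic carbon. Going by the values given here, no measured pair shows this exchange alone, so its size is open. The change from amino to methoxy is expected to cost a little, with a step of a 2.0-fold higher number from compound 1 to compound 3 (0.29 log units; within the scatter) that may still fall within the scatter. Compound 3 is therefore estimated at 120 nM in this assay, within a range of 30 nM to 500 nM.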

Compound 3, half-maximal inhibitory concentration: 245 nM
Compound 3: the middle estimate sits 2.0-fold (0.31 log units) below what was measured, within the range that was stated.
By their numbers in this assay, from the lowest: compound 1; then compound 3; then compound 2.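

In this assay the exchange of amino for methoxy on this aromatic carbon gives a 4.0-fold higher number from compound 1 to compound 3 (0.60 log units; beyond the scatter) and so shows that this position responds to the change. The exchange removes the hydrogen-bond donor of the amino group and adds a heavy atom, and this single pair cannot separate those two differences. Nothing available explains the step. 

From the compounds shown here alone, whether a hydroxy or a dimethylamino group on the same carbon would match amino or methoxy remains open. So does whether this exchange would have a similar effect with another group in place of the ethyl chain.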